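A few compounds are considered here, and "the series" means these few. Any claim that something is new, unique, unknown or untested is made for them only; others in the source may bear on it.

Measured compounds:
compound 1, `Cc1cc(C)cc(-c2cccc(S(=O)(=O)N3CCC(N4CCC(C)CC4)CC3)c2)c1`: 41 nM
compound 2, `Cc1cc(C)c(S(=O)(=O)N2CCC(C(=O)N3CCC(C)CC3)CC2)c(C)c1`: > 5000 nM
compound 3, `CC1CCN(C2CCN(S(=O)(=O)c3nccn3C)CC2)CC1`: > 5000 nM

All three were tested in a functional assay on DLD-1 cells (Homo sapiens) for antiproliferative activity, read by CellTiter-Glo, with a stated time of 72 h; on this read-out lower numbers stand for stronger inhibition and higher numbers for weaker inhibition. Compound 1 gives 41 nM, a measured number. Compound 2 reaches only the limit of the assay, > 5000 nM, so no number is known for it. Compound 3 likewise stands at the limit, > 5000 nM, and is one of the two compounds that share (the limit of > 5000 nM in this assay, at which 2 of the 3 values shown sit). Compound 3 is therefore known only to be no stronger than that limit, and where it truly lies beneath it cannot be read from the data.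

Compound 4, `CC1CCN(C2CCN(S(=O)(=O)c3ccc(Br)c(Cl)c3)CC2)CC1`, is not yet measured. It differs from compound 3 in one place: 4-bromo-3-chlorophenyl in place of 1-methyl-1H-imidazol-2-yl on a sulfonyl sulfur. The remaining part of the molecule, the sulfonamide nitrogen in a ring and what hangs from it, stays as in compound 3. For the measured compounds named here, compound 1, the only compound here with a measured number, also carries a six-membered aromatic ring of carbon only on its sulfonyl sulfur, while compound 3 carries the five-membered aromatic ring with 2 hetero atoms. From this alone, a step well beyond the scatter toward stronger inhibition is expected for an at least 12-fold lower number from compound 3 to compound 4 (1.09 log units; beyond the scatter), though a value at the limit cannot be ruled out. Compound 4 is estimated at 400 nM, within a range of 60 nM to 3000 nM.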

Compound 4, half-maximal inhibitory concentration: 12 nM
For compound 4 the middle estimate is 33-fold (1.52 log units) above the measured one; measured number outside the range, below it.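

For the compounds shown here, until now, no two measured compounds differed in only one place, so the group on the sulfonyl sulfur could not be judged on its own. In this assay, with the sulfonamide nitrogen in a ring and everything attached to it held constant, 4-bromo-3-chlorophenyl in place of 1-methyl-1H-imidazol-2-yl gives an at least 410-fold lower number from compound 3 to compound 4 (2.61 log units; beyond the scatter), which shows that this single position can decide between strong inhibition and none detected at the limit of the assay. Compound 3 has only a limit and not a measured number, so the printed step is a minimum and the true step could be larger: the limit of > 5000 nM in this assay, at which 2 of the 4 values shown sit.

The change replaces the ring and adds both halogens at once, so the compounds shown cannot separate the contribution of the six-membered carbon ring from that of the bromine or the chlorine. Plain phenyl, a phenyl ring bearing only bromine or only chlorine, and a pyridine ring on the same sulfonyl sulfur would be needed to show which of these features carries the gain.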